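A few compounds are considered here, and "the series" means these few. Any claim that something is new, unique, unknown or untested is made for them only; others in the source may bear on it.

The shared core of compound 1 `CCSC(=S)SCC(=O)c1ccc(C)cc1` has been tested in a functional assay on HeLa cells (Homo sapiens) for antiproliferative activity, read by resazurin assay (on this read-out lower numbers stand for stronger inhibition and higher numbers for weaker inhibition), where compound 1 gives 3980 nM. A second member of the series, compound 2 `CCSC(=S)SCC(=O)c1cccc(OC)c1`, has also been measured, and in this assay compound 2 gives 5010 nM. These two numbers lie within the usual scatter of one another, so on the evidence so far compound 1 cannot be set apart from compound 2. Compound 3 `Cc1ccc(C(=O)CSC(=S)SC(C)(C)C)cc1` has not yet been measured. It differs from compound 1 in one place: tert-butyl in place of ethyl on a sulfur. Within the data shown here, no measured pair in this set shows what such a change does, so the step from compound 1 to compound 3 in this assay is expected to be small, with no clear direction and possibly nothing beyond the scatter. The estimate for compound 3 is therefore 4000 nM, with a range from 1500 nM to 11000 nM, which means an expected step of a 1.0-fold higher number from compound 1 to compound 3 (0.00 log units; within the scatter).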

Compound 3, half-maximal inhibitory concentration: 31600 nM
For compound 3 the middle estimate is 7.9-fold (0.90 log units) below the measured one, and the stated range ends below it.
By their numbers in this assay, from the lowest: compounds 1 and 2 (each within the scatter of the next); then compound 3.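

The alkyl group on this sulfur clearly matters: in this assay, tert-butyl in place of ethyl gives a 7.9-fold higher number from compound 1 to compound 3 (0.90 log units; beyond the scatter), which means weaker inhibition and a step beyond the scatter. Among these compounds, this is the first sign that the position, on a sulfur whose other neighbour is the thiocarbonyl carbon, responds to a change of group, although it rests on this single pair. Nothing measured here explains why the number rises.

A straight butyl chain or an isopropyl group on the same sulfur could show whether the step follows the number of carbons or the branching, and a methyl group could show what happens with fewer carbons than ethyl. As far as these compounds go, it also remains open whether tert-butyl would give a similar step on the core of compound 2.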